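This account rests on a few compounds, and the source may have more. Where it says the series, first, only, none or still open, it means among the compounds named here.

Compound 3 `CC1(C)CC(NC(=O)NCc2ccccc2)c2cc(F)ccc2O1` is the reference point of this small series: in a functional assay on U-373MG ATCC cells (Homo sapiens) for inhibition, read by MTT assay, with a stated time of 72 h (a higher number here means a weaker inhibitor, a lower number a stronger inhibitor), compound 3 gives 11000 nM. Compound 1 `CC1(C)CC(NC(=O)Nc2ccc(Cl)cc2)c2cc(F)ccc2O1` carries the same core, and in this assay compound 1 gives 24000 nM. The step between them is a 2.2-fold higher number from compound 3 to compound 1 (0.34 log units; beyond the scatter), and the change behind it is 4-chlorophenyl in place of benzyl on an amide-type nitrogen.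

Compound 2 `CC1(C)CC(NC(=S)NCc2ccccc2)c2cc(Br)ccc2O1` has a different core; the difference between the cores of compound 2 and compound 3 is not broken down here. In this assay compound 2 gives 29000 nM, which sits within the scatter of compound 1 and beyond it only against compound 3.

Compound 4 `CC1(C)CC(NC(=S)Nc2ccc(Cl)cc2)c2cc(Br)ccc2O1` has not yet been tested. It differs from compound 2 by 4-chlorophenyl in place of benzyl on an amide-type nitrogen. Around the place the two changes are not identical: in compound 1 the amide-type nitrogen sits on a carbonyl carbon, in compound 4 on a thiocarbonyl carbon, so the change is the same kind of change, not the same. The expected step from compound 2 to compound 4 is a 1.9-fold higher number from compound 2 to compound 4 (0.28 log units; within the scatter), resting on compound 3 and compound 1 because of a 2.2-fold higher number from compound 3 to compound 1 (0.34 log units; beyond the scatter). Compound 4 is therefore estimated at 55000 nM, expected between 22000 nM and 130000 nM.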

Compound 4, half-maximal inhibitory concentration: 7000 nM
Compound 4: the middle estimate sits 7.9-fold (0.90 log units) above what was measured; measured number outside the range, below it.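

In this assay, 4-chlorophenyl in place of benzyl on an amide-type nitrogen gives a 4.1-fold lower number from compound 2 to compound 4 (0.62 log units; beyond the scatter), so on this evidence the change does not carry from one core to the other with its direction or its size intact: the same change on two cores in this assay, a 2.2-fold higher number (0.34 log units; beyond the scatter) from compound 3 to compound 1 and a 4.1-fold lower number (0.62 log units; beyond the scatter) from compound 2 to compound 4, 9.0-fold (0.96 log units) apart, beyond the scatter of two such steps. The two cores differ in more than one feature, with a carbonyl and fluorine in compound 1 and compound 3 but a thiocarbonyl and bromine in compound 2 and compound 4, so the reversal cannot be assigned to either feature. With one pair on each core, this shows that the step depends on its setting in these four compounds, but it gives no rule for any other core.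

The compounds shown leave open how the same change behaves on a core that combines a carbonyl with bromine, or a thiocarbonyl with fluorine. They also leave open how other groups on this nitrogen would compare, such as a longer chain or a phenyl ring bearing a carboxylic acid.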